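A few compounds are considered here, and "the series" means these few. Any claim that something is new, unique, unknown or untested is made for them only; others in the source may bear on it.

Working notes on the series. Among the measured compounds shown here, compound 3 `N#Cc1ccc(Cn2cc(CO/N=C/c3c(-c4ccccc4)nc4ccc(Br)cn34)nn2)cc1` is one of three compounds measured in a functional assay on the whole organism (strain NMRI) with Mus musculus as the target, with a stated time of 4 h; a lower number here means that less compound is needed, a higher number that more compound is needed for the effect. Compound 3 gives 20 mg/kg, level at the digits printed with compound 1 `Cc1ccc(-c2nc3ccc(Br)cn3c2/C=N/OCc2cn(Cc3ccc([N+](=O)[O-])cc3)nn2)cc1`, which gives 20 mg/kg; together these are the lowest of the three numbers. For the measured compounds named here, compound 2 `O=[N+]([O-])c1ccc(Cn2cc(CO/N=C/c3c(-c4ccc(F)cc4)nc4ccc(Br)cn34)nn2)cc1` gives 100 mg/kg, and the one step measured so far, a 5.0-fold higher number from compound 1 to compound 2 (0.70 log units; beyond the scatter), is the only direct reading of a single change in this set.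

Compound 4 `O=[N+]([O-])c1ccc(Cn2cc(CO/N=C/c3c(-c4ccccc4)nc4ccc(Br)cn34)nn2)cc1` is the next compound, not yet measured. It differs from compound 3 by nitro in place of cyano on an aromatic carbon, that is, 4-cyanobenzyl to 4-nitrobenzyl. Going by the values given here, no measured step touches this change; the step from compound 1 to compound 2 alters a different ring. Compound 4 shares its 4-nitrobenzyl with compound 1 and compound 2, whose values span both the low and the high end of the set, so the nitro group itself gives no clear signal. Compound 4 is therefore expected near compound 3, with a step of a 1.5-fold higher number from compound 3 to compound 4 (0.18 log units; within the scatter) not beyond the scatter, at an estimated 30 mg/kg with a range of 10 mg/kg to 100 mg/kg.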

Compound 4, minimum effective dose: 40 mg/kg
Estimate against measurement, compound 4: 1.3-fold (0.12 log units) below; low and high end bracket the measured number.
By their numbers in this assay, from the lowest: compounds 1, 3 and 4 (each within the scatter of the next); then compound 2.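

In this assay, going from 4-cyanobenzyl to 4-nitrobenzyl gives a 2.0-fold higher number from compound 3 to compound 4 (0.30 log units; within the scatter), so cyano and nitro cannot be told apart on this aromatic carbon, para to a large group. With the 4-nitrobenzyl held constant, the other aromatic ring can now be read at its substituted carbon: hydrogen in place of fluoro gives a 2.5-fold lower number from compound 2 to compound 4 (0.40 log units; beyond the scatter), and hydrogen in place of methyl gives a 2.0-fold higher number from compound 1 to compound 4 (0.30 log units; within the scatter). On that ring, only the fluoro of compound 2 separates from hydrogen beyond the scatter, and the methyl of compound 1 does not.

Nothing in hand accounts for these steps. Still open, going by these compounds, is whether an amine or a carboxylic acid in place of the nitro group stays within the scatter of compound 4, and whether the fluoro step carries over to the 4-cyanobenzyl series.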